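Stereochemistry at a chain carbon: compound 2 to compound 4

The source may report more compounds than this note shows. Statements on the series, on what has been measured and on what is new or still open speak of the compounds shown alone.

Measured in a functional assay on A2780 ADR cells (Homo sapiens) for cytotoxicity, read by MTT assay, with a stated time of 24 h; a lower number here means a stronger inhibitor, a higher number a weaker inhibitor:
- compound 1 `CCCCC[C@H](CCC[C@@H]1CC=CC(=O)O1)OC`: 20500 nM
- compound 2 `CCCCC[C@@H](C[C@H](O)C[C@@H]1CC=CC(=O)O1)OC`: 26300 nM
- compound 3 `CCCCC[C@@H](C[C@@H](O)C[C@H]1CC=CC(=O)O1)OC`: 25200 nM

All three values lie within the scatter of one another, so compound 2 at 26300 nM is not set apart from the others. Next in the series is compound 4 `CCCCC[C@H](C[C@H](O)C[C@@H]1CC=CC(=O)O1)OC`. The change is the two compounds have the same atoms and bonds and differ only in configuration as drawn: 1 of 3 stereo elements differ; a stereocentre at a saturated chain carbon is drawn S in compound 2 and R in compound 4.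

Among the compounds with values here, one measured step bears on this, a 1.0-fold lower number from compound 2 to compound 3 (0.02 log units; within the scatter). It concerns (the fact that compounds 2 and 3 differ only in the configuration as drawn), and it is small although two stereo elements differ. However, the chain carbon changed in that step is not the one changed in compound 4, so the support is indirect. Within the data shown here, no measured step isolates this stereocentre. Among the measured compounds shown here, with compound 3 at 25200 nM as the only precedent for a change of configuration, no shift beyond the scatter is expected in this assay.

The expected step is a 1.1-fold lower number from compound 2 to compound 4 (0.02 log units; within the scatter).

For compound 4 the estimated value is 25000 nM, with an expected range of 13000 nM to 48000 nM.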

Compound 4, half-maximal inhibitory concentration: 30000 nM
Compound 4: the middle estimate sits 1.2-fold (0.08 log units) below what was measured; low and high end bracket the measured number.
By their numbers in this assay, from the lowest: compounds 1, 3, 2 and 4 (each within the scatter of the next).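

In this assay, inverting this saturated chain carbon alone gives a 1.1-fold higher number from compound 2 to compound 4 (0.06 log units; within the scatter), so the one stereocentre that the earlier pair left unisolated now has its own step, and that step stays within the scatter: the fact that compounds 2 and 4 differ only in the configuration as drawn The mirror-image pair reads the same way, with a 1.2-fold higher number from compound 3 to compound 4 (0.08 log units; within the scatter), so inverting all three stereo elements together also separates nothing: the fact that compounds 3 and 4 differ only in the configuration as drawn Hydroxy in place of hydrogen on a saturated chain carbon bound to two saturated chain carbons gives a 1.5-fold higher number from compound 1 to compound 4 (0.17 log units; within the scatter), so among these four compounds neither that hydroxy nor configuration sets any compound apart.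

On these data alone, whether an amine or a carboxylic acid in place of the hydroxy, or a longer chain, would give a step beyond the scatter in this assay remains open. As far as these compounds go, the effect of the ring stereocentre taken alone also remains open.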